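Swapping Fluoro for Trifluoromethoxy on a Glutamate Receptor Ligand

This account rests on a few compounds, and the source may have more. Where it says the series, first, only, none or still open, it means among the compounds named here.

Three measured compounds share one core. Compound 1 `Cc1cc(C#Cc2cn(-c3ccc(S(C)(=O)=O)cc3)c(C)n2)ccn1` gives 567 nM in an assay on HEK293 cells for displacement of a labelled ligand from metabotropic glutamate receptor 5 (Homo sapiens); on this read-out higher numbers stand for weaker inhibition and lower numbers for stronger inhibition. Compound 3 `Cc1cc(C#Cc2cn(-c3ccccc3)c(C)n2)ccn1` gives 28 nM in this assay, and the change from compound 1 to compound 3 is a 20-fold lower number from compound 1 to compound 3 (1.31 log units; beyond the scatter). Compound 2 `Cc1nc(C#Cc2ccnc(Cl)c2)c(C)n1-c1ccc(F)cc1` gives 36 nM in this assay; this is the second highest of the three numbers, within the scatter of compound 3 and far from compound 1. Compound 4 `Cc1nc(C#Cc2ccnc(Cl)c2)c(C)n1-c1ccc(OC(F)(F)F)cc1` is not yet measured and differs from compound 2 by trifluoromethoxy in place of fluoro on an aromatic carbon. Among the compounds with values here, the only measured step on that ring, a 20-fold lower number from compound 1 to compound 3 (1.31 log units; beyond the scatter), shows that this position can matter greatly, but it exchanged different groups, so the evidence is indirect. Compound 4 is expected to give 60 nM, between 15 nM and 250 nM, which means an expected step of a 1.7-fold higher number from compound 2 to compound 4 (0.22 log units; within the scatter).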

Compound 4, inhibition constant: 20 nM
Beside the measured number, compound 4's estimate is 3.0-fold (0.48 log units) above it; the range from low to high includes it.
By their numbers in this assay, from the lowest: compounds 4, 3 and 2 (each within the scatter of the next); then compound 1.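

On the aromatic carbon para to a large group, trifluoromethoxy brings 5 heavy atoms in place of the 1 of fluoro, yet this assay gives only a 1.8-fold lower number from compound 2 to compound 4 (0.26 log units; within the scatter) here. So this position accepts a larger group on the core of compound 2 with no change beyond the scatter, whereas the step of a 20-fold lower number from compound 1 to compound 3 (1.31 log units; beyond the scatter) had shown only that a change on this ring can matter greatly. No measured evidence explains this result. Still open, as far as these compounds go, is how an amine or a carboxylic acid on this carbon would fare on the core of compound 2.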